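This account rests on a few compounds, and the source may have more. Where it says the series, first, only, none or still open, it means among the compounds named here.

Three compounds of one series share a core carrying an amino-substituted bicyclic ring and a flexible chain ending in an amide or a hydroxamic acid. Compound 1 `CNC(=O)CCCCCCCn1nc(-c2ccc3oc(N)nc3c2)c2c(N)ncnc21` gives 10700 nM in a functional assay on SK-HEP1 cells (Homo sapiens) for inhibition, read by MTT assay, with a stated time of 72 h; on this read-out higher numbers stand for weaker inhibition and lower numbers for stronger inhibition. Compound 2 `Nc1nc2cc(-c3nn(CCCCCC(=O)NO)c4ncnc(N)c34)ccc2o1` gives 3080 nM in this assay, and the step from compound 1 to compound 2 is a 3.5-fold lower number from compound 1 to compound 2 (0.54 log units; beyond the scatter). Compound 3 `Nc1ncnc2c1c(-c1cnc3[nH]ccc3c1)nn2CCCCCCC(=O)NO` gives 14700 nM in this assay, the highest of the three numbers; its gap to compound 1 lies within the scatter, while its gap to compound 2 lies beyond it.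

Compound 4 `Nc1ncnc2c1c(-c1cnc3[nH]ccc3c1)nn2CCCCCC(=O)NO` has not yet been measured. It differs from compound 3 by hydroxycarbamoyl in place of (hydroxycarbamoyl)methyl on a saturated chain carbon, five bonds along the chain from an aromatic nitrogen. This shortens the chain by one carbon, leaving the hydroxamic acid end in place, so compound 4 carries the same chain as compound 2. Going by the values given here, the only measured step, from compound 1 to compound 2, changes both the chain length and the end group at once, so it bears on this change only loosely. Among the compounds with values here, with no step of the same kind on record, compound 4 is expected to land close to compound 3, with at most a small shift downward, as in a 1.5-fold lower number from compound 3 to compound 4 (0.17 log units; within the scatter). The estimate for compound 4 in this assay is 10000 nM, between 3500 nM and 30000 nM.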

Compound 4, half-maximal inhibitory concentration: > 150000 nM
Compound 4: no number, only a limit; the forecaster's own chance of this, stated with the estimate: 5%; at least 15-fold (1.17 log units) between middle value and limit.
By their numbers in this assay, from the lowest: compound 2; then compounds 1 and 3 (each within the scatter of the next). At a limit, above all of these: compound 4.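

In this assay, putting hydroxycarbamoyl in place of (hydroxycarbamoyl)methyl, on a saturated chain carbon five bonds along the chain from an aromatic nitrogen, gives an at least 10-fold higher number from compound 3 to compound 4 (1.00 log units; beyond the scatter), so the chain length at this position is far from neutral even though the hydroxamic acid end stays in place. For compound 4 the entry is a limit and not a number: the limit of > 150000 nM in this assay, at which 1 of the 4 values shown sits. The shorter chain alone does not settle the outcome, since compound 2, which carries the same chain with a different ring group on the shared core, gives 3080 nM, so the effect of this chain change seems to depend on the ring group it is paired with.

Going by these compounds alone, what stays open is whether a longer chain than the one in compound 3 would lower the number with this ring group, and whether a carboxylic acid or an amine at the chain end would behave as the hydroxamic acid does. The full size of the step also remains unknown, and the compounds shown do not tell why so small a change in the chain has so large an effect.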